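Fluoro on the Aromatic Ring of Compound 2

The compounds below may be only part of what the source reports. "The series", "measured", "known", "first", "only" and "open" are said of these compounds alone.

Compound 1 `C#CCNC(=O)/C(C)=C(\C)c1ccc(OC)cc1` gives 150 mg/kg in a toxicity assay on the whole organism (strain Icem-CET (SPF Caw)) for cytotoxicity, with Mus musculus as the target; on this read-out higher numbers stand for an effect only at larger amounts of compound and lower numbers for an effect already at smaller amounts.
Compound 2 `C#CCNC(=O)/C(C)=C(\C)c1ccccc1` gives 150 mg/kg in this assay.
Compound 3 `C/C(C(=O)NC1CC1)=C(/C)c1ccccc1` gives 150 mg/kg in this assay.

On these numbers compound 2 stands level with compounds 1 and 3: all three share the same amide-type core and the same read-out, and neither of the two changes made so far moved the result beyond the usual scatter. The step of no change at the digits printed from compound 1 to compound 2 (within the scatter) exchanged a group on an aromatic carbon for hydrogen without any shift, and the step of no change at the digits printed from compound 2 to compound 3 (within the scatter) swapped the group on the amide-type nitrogen with the same outcome.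

Compound 4 `C#CCNC(=O)/C(C)=C(\C)c1ccc(F)cc1` differs from compound 2 by fluoro in place of hydrogen on an aromatic carbon. The measured step that bears on this change is the one that also altered a group on an aromatic carbon of the ring, namely no change at the digits printed from compound 1 to compound 2 (within the scatter), and it was flat. A change of one small atom at the same kind of position is therefore expected to give no step beyond the scatter, so the expected step is no change at the digits printed from compound 2 to compound 4 (within the scatter). Compound 4 is accordingly estimated to give 150 mg/kg in this assay, with a range from 75 mg/kg to 300 mg/kg.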

Compound 4, dose for half-maximal effect: 100 mg/kg
Beside the measured number, compound 4's estimate is 1.5-fold (0.18 log units) above it; the range from low to high includes it.
By their numbers in this assay, from the lowest: compounds 4, 1, 2 and 3 (each within the scatter of the next).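

In this assay, fluoro in place of hydrogen on an aromatic carbon, para to a large group, gives a 1.5-fold lower number from compound 2 to compound 4 (0.18 log units; within the scatter). This adds a halogen to the groups tried at this carbon, and the direct comparison of the two groups that replace hydrogen there gives a 1.5-fold lower number from compound 1 to compound 4 (0.18 log units; within the scatter), so hydrogen, methoxy and fluoro can be exchanged here in either direction without a step beyond the scatter, at least among compounds 1, 2 and 4. No supporting measurement is available to explain this result, so the numbers describe what happens at this carbon and not the reason for it.

The compounds shown leave open whether an amine, a carboxylic acid or a longer chain on this same aromatic carbon would give a step beyond the scatter, or whether the insensitivity seen so far extends to groups of that kind. They also leave open whether fluoro at this carbon would give the same kind of result with cyclopropyl in place of propargyl on the amide-type nitrogen, the change that links compound 2 to compound 3.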